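This account rests on a few compounds, and the source may have more. Where it says the series, first, only, none or still open, it means among the compounds named here.

Measured compounds:
compound 1, `N/C(=N\C(=O)CC(c1ccccc1)c1ccccc1)NCCCc1ccccn1`: 5.68
compound 2, `CC(CC(=O)/N=C(\N)NCCCc1ncc[nH]1)c1cccs1`: 5.26

In a functional assay on Sf9 cells for antagonist activity at histamine H2 receptor (Homo sapiens), with stated times of 2 min and 20 min (a higher number here means a more potent compound, by a factor of ten per unit of this negative logarithm, a lower number a less potent compound), compound 1 gives 5.68, the higher of the two numbers shown. Among the compounds with values here, compound 2 gives 5.26, a gap beyond the scatter, but the two structures differ in more than one place, so no single step is read from them. Compound 3, `N/C(=N\C(=O)CC(c1ccccc1)c1ccccc1)NCCCc1cn[nH]c1`, differs from compound 1 by 1H-pyrazol-4-yl in place of pyridin-2-yl on a saturated chain carbon, three bonds along the chain from an amine nitrogen. Within the data shown here, no measured pair isolates this change. In this assay a small loss, near the edge of the scatter, is expected, the step being a number 0.28 log units lower from compound 1 to compound 3 (within the scatter). Compound 3 is estimated at 5.4, range 4.8 to 6.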

Compound 3, negative logarithm of the antagonist equilibrium constant: 5.42
The estimate for compound 3 lay 0.02 log units below the measured number; the range from low to high includes it.
By their numbers in this assay, from the lowest: compounds 2, 3 and 1 (each within the scatter of the next, the first and the last beyond it).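

Within the data shown here, the first single-place comparison is 1H-pyrazol-4-yl in place of pyridin-2-yl on a saturated chain carbon, three bonds along the chain from an amine nitrogen. In this assay this change gives a number 0.26 log units lower from compound 1 to compound 3 (within the scatter) and so separates the two compounds by no more than repeat measurements would. The position therefore accepts a five-membered ring carrying a hydrogen-bond donor in place of the six-membered ring, and nothing available explains this outcome.

Going by these compounds, whether a phenyl ring or a primary amine at this place would hold the number remains open. So does the effect of a longer chain.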